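The source may report more compounds than this note shows. Statements on the series, on what has been measured and on what is new or still open speak of the compounds shown alone.

Compound 1, `Cc1ccccc1-n1nncc1CN1C(=O)C2(C(C#N)=C(N)Oc3c2c2nc4ccccc4nc2c2ccccc32)c2ccccc21`, is tested in an ADME assay on L02 cells (Homo sapiens) for antiproliferative activity, read by MTT assay, with a stated time of 48 h; on this read-out lower numbers stand for stronger inhibition and higher numbers for weaker inhibition. In this assay compound 1 gives only a limit, > 50000 nM. Compound 2, `N#CC1=C(N)Oc2c(c3nc4ccccc4nc3c3ccccc23)C12C(=O)N(Cc1cnnn1-c1ccc(N)cc1)c1ccccc12`, likewise gives only a limit in this assay, > 50000 nM. For the measured compounds named here, the one measured pair that differs in a single place is a step that the two limits leave unreadable from compound 1 to compound 2, both of its ends sitting at the limit of > 50000 nM in this assay, at which 3 of the 3 values shown sit. Compound 3, `N#CC1=C(N)Oc2c(N)cc3nc4ccccc4nc3c2C12C(=O)N(Cc1cnnn1-c1ccc(Cl)cc1)c1ccccc12`, stands in the same place: in this assay compound 3 gives a limit, > 50000 nM. Since every value shown sits at that limit, compound 3 cannot be set above or below either of the other two.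

Compound 4, `N#CC1=C(N)Oc2c(N)cc3nc4ccccc4nc3c2C12C(=O)N(Cc1cnnn1-c1ccc(Cl)cc1Cl)c1ccccc12`, has not yet been measured in this assay. It differs from compound 3 by chloro in place of hydrogen on an aromatic carbon; cut one bond further out, the change reads as 4-chlorophenyl to 2,4-dichlorophenyl. Going by the values given here, the only measured step that alters the aryl group on the aromatic nitrogen is the one from compound 1 to compound 2, and its size is not readable because the limit of > 50000 nM in this assay, at which 3 of the 3 values shown sit, holds both of its ends. Among the compounds with values here, no measured step shows what one added chloro on this ring does to the read-out. The expectation for compound 4 is therefore that it stays at the limit, with an estimated step that the limit leaves unreadable from compound 3 to compound 4 no larger than the scatter. Compound 4 is expected to give 60000 nM, between 20000 nM and 200000 nM.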

Compound 4, half-maximal inhibitory concentration: > 50000 nM
Compound 4 gave a limit, no number (the forecaster's own chance of this, stated with the estimate: 85%); the middle value is on the limit's open side.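

In this assay compound 4 gives only a limit, > 50000 nM, so the step from compound 3 to compound 4 cannot be read, and all values shown sit at the same place: the limit of > 50000 nM in this assay, at which 4 of the 4 values shown sit.

From the compounds shown here alone, what the chloro on the ring does to the read-out, and how compound 1, compound 2, compound 3 and compound 4 rank, stays open.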